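The compounds below may be only part of what the source reports. "The series", "measured", "known", "first", "only" and "open" are said of these compounds alone.

Measured so far:
- compound 1, `CC(C)(C)[C@@H](O)C(=O)N1CSC[C@H]1C(=O)NCc1cc(Cl)ccc1-n1cnnn1`: 19 10^-6 cm/s
- compound 2, `O=C(NCc1cc(Cl)ccc1-n1cnnn1)[C@@H]1[C@H]2C[C@H]2CN1C(=O)[C@H](O)CC1CC1`: 3.4 10^-6 cm/s
- compound 3, `O=C(NCc1cc(Cl)ccc1-n1cnnn1)[C@@H]1CC=NN1C(=O)[C@H](O)C1CCCCC1`: 19 10^-6 cm/s

All three were run in an ADME assay on Caco-2 cells (Homo sapiens) for permeability, read by LC-MS, in the apical to basolateral direction, with a stated time of 60 min, at pH 6.5; on this read-out higher numbers stand for higher permeability and lower numbers for lower permeability. Compound 2 has the lowest number of the three. Its nearest neighbour is compound 1, whose number is higher by a margin beyond the scatter; compound 3 sits at the same distance above it, also beyond the scatter. Compound 1 and compound 3, with different cores and different groups at the hydroxyl-bearing carbon, give numbers that lie within the scatter of each other.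

Compound 4, `CC(C)(C)[C@@H](O)C(=O)N1C[C@@H]2C[C@@H]2[C@H]1C(=O)NCc1cc(Cl)ccc1-n1cnnn1`, keeps the core of compound 2 and carries the same group as compound 1 at the hydroxyl-bearing carbon. The change from compound 2 to compound 4 is tert-butyl in place of cyclopropylmethyl on a saturated chain carbon bound to a carbonyl carbon and an oxygen on a saturated carbon. Within the data shown here, no measured pair shows this change by itself, so its size must be judged from the values at hand.

Because compound 2 gives 3.4 10^-6 cm/s while compound 1 gives 19 10^-6 cm/s, a moderate upward step in this assay is expected, though the shared core of compound 2 and compound 4 may hold the number down. The expected step is a 1.6-fold higher number from compound 2 to compound 4 (0.21 log units; within the scatter). For compound 4 the estimate is 5.5 10^-6 cm/s, with a likely range from 2.5 10^-6 cm/s to 13 10^-6 cm/s.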

Compound 4, apparent permeability: 17 10^-6 cm/s
Estimate against measurement, compound 4: 3.1-fold (0.49 log units) below; the whole stated range lies below it.
By their numbers in this assay, from the lowest: compound 2; then compounds 4, 1 and 3 (each within the scatter of the next).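

In this assay, among these compounds, putting tert-butyl in place of cyclopropylmethyl on a saturated chain carbon bound to a carbonyl carbon and an oxygen on a saturated carbon gives a 5.0-fold higher number from compound 2 to compound 4 (0.70 log units; beyond the scatter) and is the first change here made in one place alone. Both groups have 4 heavy atoms, all carbon, with no hydrogen-bond donors or acceptors and no net charge, so these counts do not separate them, and the visible difference is that cyclopropylmethyl holds a three-membered ring while tert-butyl has none. With tert-butyl at this position, the core of compound 2 no longer goes with the lowest number, as compound 4 gives 17 10^-6 cm/s and compound 1, which differs from it only in the core, gives 19 10^-6 cm/s in values within the scatter of each other.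

Nothing shown here measures why the step has this size. As far as these compounds go, it also remains open how this position would respond to an amine or a longer chain, and whether the same swap gives a similar step on the core of compound 1.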